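The source may hold more compounds than are shown below. What is called first, only, known or untested is meant among the compounds shown, and "the series" means these compounds.

Compound 1 `COc1cc(NC(=O)Nc2cc(Nc3cc(Br)ccc3OC)ncn2)cc(OC)c1` gives 23.1% in a functional assay on NCI-H1581 cells (Homo sapiens) for inhibition, read by MTT assay, with a stated time of 48 h, tested at 10 uM (a lower number here means less inhibition, a higher number more inhibition at the concentration tested (going by the name of the read-out)), the lowest of the three numbers recorded; compound 3 `COc1ccc(Nc2cc(NC(=O)Nc3c(Cl)cccc3Cl)ncn2)cc1C` gives 45.1% and compound 2 `COc1cc(NC(=O)Nc2cc(Nc3cc(C(F)(F)F)ccc3OC)ncn2)cc(OC)c1` gives 67.1%, both beyond the scatter above it. Compound 4 `COc1cc(NC(=O)Nc2cc(Nc3ccc(C)c(C)c3)ncn2)cc(OC)c1` differs from compound 1 by 3,4-dimethylphenyl in place of 5-bromo-2-methoxyphenyl on a nitrogen on an aromatic ring. Among the compounds with values here, the only step measured in one place, a number 44 percentage points higher from compound 1 to compound 2 (beyond the scatter), touches the same ring that is exchanged here and shows that an alteration on that ring can move the read-out strongly upward. The present change is a larger one, replacing the whole ring, so a rise is expected but with wide uncertainty, a number 14.9 percentage points higher from compound 1 to compound 4 (beyond the scatter). Compound 4 is therefore estimated at 38%, within 12% to 65%.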

Compound 4, a percentage reported as inhibition, at one concentration (the size of the read-out at that concentration, not a potency): 20.1%
Beside the measured number, compound 4's estimate is 17.9 percentage points above it, within the range that was stated.
By their numbers in this assay, from the lowest: compounds 4 and 1 (each within the scatter of the next); then compound 3; then compound 2.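

Within the data shown here, exchanging the whole ring on this nitrogen, 5-bromo-2-methoxyphenyl for 3,4-dimethylphenyl, gives a number 3 percentage points lower from compound 1 to compound 4 (within the scatter) in this assay, so this larger change leaves the read-out within the scatter, while the single exchange of bromo for trifluoromethyl gave a number 44 percentage points higher from compound 1 to compound 2 (beyond the scatter). The bromo and methoxy groups leave together here, so their separate contributions cannot be told apart. No available evidence accounts for this outcome. On these data alone, it remains open whether trifluoromethyl on the 3,4-dimethylphenyl ring would raise the read-out. A carboxylic acid or a primary amine on this ring is also untested in the compounds shown.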